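The compounds below may be only part of what the source reports. "The series", "measured", "known", "first", "only" and "open" are said of these compounds alone.

Measured compounds: compound 1 `O=c1ccc(-c2ccc3cn[nH]c3c2)cn1Cc1ccccc1C(F)(F)F` gives 100 nM in an assay for inhibition of MAP kinase-interacting serine/threonine-protein kinase 2 (Homo sapiens), read by luminescence and ADP-Glo, with a stated time of 2 h; a higher number here means a weaker inhibitor, a lower number a stronger inhibitor; compound 2 `CC(=O)Nc1cccc(Cn2cc(-c3ccc4cn[nH]c4c3)ccc2=O)c1` gives 43 nM; compound 3 `O=c1ccc(-c2ccc3cn[nH]c3c2)cn1Cc1cccc(C(F)(F)F)c1` gives 32 nM.

Compound 1 stands at the highest number of the three in this assay; compound 2 lies lower by a gap beyond the scatter, and compound 3 lower still. Compound 4 `NC(=O)c1ccccc1Cn1cc(-c2ccc3cn[nH]c3c2)ccc1=O` differs from compound 1 by carbamoyl in place of trifluoromethyl on an aromatic carbon. Going by the values given here, one measured step bears on this change: a 1.3-fold lower number from compound 2 to compound 3 (0.13 log units; within the scatter), an exchange of a trifluoromethyl for an acetamido on the same kind of ring, though at a different place; it stayed within the scatter. The step is therefore expected to be small, no change at the digits printed from compound 1 to compound 4 (within the scatter), with no clear direction. Compound 4 is estimated at 100 nM in this assay, with a range from 40 nM to 250 nM.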

Compound 4, half-maximal inhibitory concentration: 340 nM
Compound 4: the middle estimate sits 3.4-fold (0.53 log units) below what was measured; measured number above the stated range.
By their numbers in this assay, from the lowest: compounds 3 and 2 (each within the scatter of the next); then compound 1; then compound 4.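

In this assay, going by these compounds alone, carbamoyl in place of trifluoromethyl on an aromatic carbon ortho to a large group gives a 3.4-fold higher number from compound 1 to compound 4 (0.53 log units; beyond the scatter) and so goes beyond the scatter, while the only earlier exchange, at a different place on the ring, was a 1.3-fold lower number from compound 2 to compound 3 (0.13 log units; within the scatter) and stayed within it. Within the data shown here, this position therefore responds to the group it carries, which the earlier compounds could not show. Nothing at hand accounts for the higher number.

On these data alone, whether a carboxylic acid or an amine at this position would raise the number further remains open. So does whether carbamoyl at the place of the groups in compound 2 and compound 3 would give a similar step.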